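The source may hold more compounds than are shown below. What is called first, only, known or untested is meant among the compounds shown, and "the series" means these compounds.

Compound 3 `Brc1cccc([C@@H]2C[C@@H]3Cc4ccc5ccccc5c4N2O3)c1` is one of three compounds tested in an ADME assay on THP-1 cells (Homo sapiens) for cytotoxicity, read by MTT assay, with a stated time of 72 h; on this read-out lower numbers stand for higher toxicity in this test and higher numbers for lower toxicity in this test. In this assay compound 3 gives only a limit, > 250000 nM. Compound 1 `Clc1ccc([C@@H]2C[C@@H]3Cc4ccc5ccccc5c4N2O3)cc1` likewise reaches only a limit in this assay, > 300000 nM. Compound 2 `Brc1ccc([C@@H]2C[C@@H]3Cc4ccc5ccccc5c4N2O3)cc1` also stops at a limit in this assay, > 250000 nM. The steps a step that the two limits leave unreadable from compound 1 to compound 3, a step that the two limits leave unreadable from compound 2 to compound 3 and a step that the two limits leave unreadable from compound 1 to compound 2 therefore have no readable size, since every value sits at a limit (the limit of > 250000 nM in this assay, at which 2 of the 3 values shown sit, (the limit of > 300000 nM in this assay, at which 1 of the 3 values shown sits)). Compound 4 `Clc1ccccc1[C@@H]1C[C@@H]2Cc3ccc4ccccc4c3N1O2` differs from compound 3 by 2-chlorophenyl in place of 3-bromophenyl on a saturated ring carbon. Among the measured compounds shown here, no measured step in this assay bears on that change with a readable size. Compound 4 is therefore expected to give about 300000 nM in this assay, within 100000 nM to 1000000 nM, most likely again as a limit. The step that the limit leaves unreadable from compound 3 to compound 4 expected from this is none beyond the scatter.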

Compound 4, half-maximal cytotoxic concentration: > 300000 nM
Compound 4 was reported as a limit; the forecaster's own chance of this, stated with the estimate: 85%; the middle value sits exactly at the limit.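

In this assay, among the compounds shown here, compound 4 stops at a limit, as do compounds 1, 2 and 3, so no step among them can be read. The compounds shown leave open whether changing the halogen-bearing phenyl group alters toxicity at all.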